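Two amides on a shared sulfamate core, one still unmeasured

The source may report more compounds than this note shows. Statements on the series, on what has been measured and on what is new or still open speak of the compounds shown alone.

Compound 2 `CC(C)CCN(CCC(C)C)c1cccc(C(=O)N2CCc3ccc(OS(N)(=O)=O)cc3C2)c1` stands highest of the two measured compounds in an assay on HEK293 cells for inhibition of Steryl-sulfatase (Homo sapiens), tested at 1 uM (a lower number here means a weaker effect, a higher number a stronger effect of the compound at the concentration tested), giving 75.9%. Compound 1 `NS(=O)(=O)Oc1ccc2c(c1)CN(C(=O)c1cccc(N3CCC(Cc4ccccc4)CC3)c1)CC2` gives 41.9% in this assay, a gap beyond the usual scatter. Compound 3 `CCN(Cc1ccccc1)c1cccc(C(=O)N2CCc3ccc(OS(N)(=O)=O)cc3C2)c1` has not yet been measured; it differs from compound 2 by benzyl(ethyl)amino in place of diisopentylamino on an aromatic carbon. Within the data shown here, with no measured pair showing this change, the expected step from compound 2 to compound 3 is a moderate loss, a number 15.9 percentage points lower from compound 2 to compound 3 (beyond the scatter), since compound 1 with its ring-bearing group gives 41.9%. Compound 3 is therefore expected to give about 60%, within 35% to 80%.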

Compound 3, a percentage reported as inhibition, at one concentration (the size of the read-out at that concentration, not a potency): 69%
The estimate for compound 3 lay 9 percentage points below the measured number; measured number inside the range.
By their numbers in this assay, from the lowest: compound 1; then compounds 3 and 2 (each within the scatter of the next).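

In this assay, benzyl(ethyl)amino in place of diisopentylamino on the aromatic carbon gives a number 6.9 percentage points lower from compound 2 to compound 3 (within the scatter). At this position, then, a group with a six-membered aromatic ring of carbon only and a group with no ring cannot be told apart by this read-out. Nothing measured here bears on why the two groups read alike. On these data alone, whether dimethylamino at this place, or a carboxylic acid on the benzyl group, would keep the read-out at this level stays open.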